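Working notes on three measured compounds and one expected

The source may report more compounds than this note shows. Statements on the series, on what has been measured and on what is new or still open speak of the compounds shown alone.

Measured so far in a functional assay on MCF7 cells (Homo sapiens) for cytotoxicity, read by MTT assay, with a stated time of 24 h; on this read-out higher numbers stand for weaker inhibition and lower numbers for stronger inhibition:
Compound 1 `COc1ccc(-c2nnc(N3CCN(C(=O)CN4CCN(c5cccc(Cl)c5)CC4)CC3)nc2-c2ccc(OC)cc2)cc1`: compound 1 gives > 814000 nM, a limit of the assay and not a number.
Compound 2 `COc1ccc(-c2nnc(N3CCN(C(=O)CN4CCN(c5ccc(OC)cc5)CC4)CC3)nc2-c2ccc(OC)cc2)cc1`: compound 2 gives > 821000 nM, a limit of the assay and not a number.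
Compound 3 `O=C(CN1CCN(c2cccc(Cl)c2)CC1)N1CCN(c2nnc(-c3ccc(Cl)cc3)c(-c3ccc(Cl)cc3)n2)CC1`: compound 3 gives > 803000 nM, a limit of the assay and not a number.

For the measured compounds named here, no compound of the three returns a number. For compound 1 the boundary is the limit of > 814000 nM in this assay, at which 1 of the 3 values shown sits. For compound 2 the boundary is the limit of > 821000 nM in this assay, at which 1 of the 3 values shown sits. For compound 3 the boundary is the limit of > 803000 nM in this assay, at which 1 of the 3 values shown sits. With all three at a boundary, no order among them can be stated.

From compound 1 to compound 2 the change is 4-methoxyphenyl in place of 3-chlorophenyl on an amine nitrogen in a ring. The step that the two limits leave unreadable from compound 1 to compound 2 has no readable size because the limit of > 814000 nM in this assay, at which 1 of the 3 values shown sits, and the limit of > 821000 nM in this assay, at which 1 of the 3 values shown sits, both apply, so nothing can be said about what this change does in this assay.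

Compound 3 and compound 1 differ in more than one place; the difference between the two cores is not broken down here.

Compound 4 `COc1ccc(N2CCN(CC(=O)N3CCN(c4nnc(-c5ccc(Cl)cc5)c(-c5ccc(Cl)cc5)n4)CC3)CC2)cc1` is not yet measured. It arises from compound 3 by 4-methoxyphenyl in place of 3-chlorophenyl on an amine nitrogen in a ring, the same change as from compound 1 to compound 2 and at the same place.

Going by the values given here, the step that the limit leaves unreadable from compound 3 to compound 4 is expected to be as unreadable as the earlier step that the two limits leave unreadable from compound 1 to compound 2, which is the only comparison available for this change. This expectation rests on compound 3 standing at > 803000 nM. Compound 4 is expected to give 1000000 nM in this assay, with an expected range from 300000 nM to 5000000 nM, most probably again only a limit.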

Compound 4, half-maximal inhibitory concentration: > 809000 nM
Compound 4 was reported as a limit; the forecaster's own chance of this, stated with the estimate: 90%; the middle value does not contradict the limit.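

In this assay, compound 3 and compound 4 each stand at a limit of the assay and not at a number, and the step between these two compounds cannot be read. The compounds shown leave open whether 4-methoxyphenyl in place of 3-chlorophenyl changes the read-out of this assay at all, with either core, and how strong any compound of this series would be on a measurable scale.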